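Removing the bromo group from a compound at the limit

The source may report more compounds than this note shows. Statements on the series, on what has been measured and on what is new or still open speak of the compounds shown alone.

In a functional assay on SGC-7901 cells (Homo sapiens) for antiproliferative activity, read by sulforhodamine B assay, with a stated time of 72 h (on this read-out lower numbers stand for stronger inhibition and higher numbers for weaker inhibition), compound 1 (`COc1ccccc1NC(=S)N/N=C/c1ccc2ccccc2n1`) gives > 100000 nM as a limit of the assay, not a number. Compound 2 (`S=C(N/N=C/c1ccc2ccccc2n1)Nc1ccccc1Br`) gives > 100000 nM and stands at that limit too. Bromo in place of methoxy is thus a step that the two limits leave unreadable from compound 1 to compound 2 and offers no size to carry over. Compound 3 (`S=C(N/N=C/c1ccc2ccccc2n1)Nc1ccccc1`) has hydrogen in place of bromo on an aromatic carbon. Only the shared limit (the limit of > 100000 nM in this assay, at which 2 of the 2 values shown sit) bears on this change, so no step beyond the scatter is expected in this assay and no direction can be given. The expected step is a number no higher from compound 2 to compound 3 (the limit leaves the size open) in estimate. For compound 3 the estimate is 100000 nM within an expected range of 30000 nM to 200000 nM as measured here.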

Compound 3, half-maximal inhibitory concentration: 26500 nM
Estimate against measurement, compound 3: 3.8-fold (0.58 log units) above; measured number below the stated range.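

With hydrogen at this place on the aromatic ring, this assay gives the only number among these compounds that is not a limit, so this position does influence the read-out. Hydrogen in place of bromo gives an at least 3.7-fold lower number from compound 2 to compound 3 (0.57 log units; beyond the scatter), and hydrogen in place of methoxy gives an at least 3.7-fold lower number from compound 1 to compound 3 (0.57 log units; beyond the scatter). Both steps are minimum sizes, since compounds 1 and 2 each stand at a limit of the assay: the limit of > 100000 nM in this assay, at which 2 of the 3 values shown sit.

On these data alone, the true size of either step stays open. So does how an amine or a carboxylic acid at this place would read.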